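Swapping the Aryl Group on the Central Nitrogen

The source may report more compounds than this note shows. Statements on the series, on what has been measured and on what is new or still open speak of the compounds shown alone.

Of the compounds shown here, two built on the same core have been measured in an in vitro assay on BHK cells for binding affinity to Glucagon receptor (Homo sapiens); a higher number here means a weaker inhibitor, a lower number a stronger inhibitor. Compound 1 `O=C(O)CCNC(=O)c1ccc(CN(c2ccc(Cl)cc2)c2nc(-c3ccc(OC(F)(F)F)cc3)cs2)cc1` gives 53 nM, and compound 2 `Cc1cc(N(Cc2ccc(C(=O)NCCC(=O)O)cc2)c2nc(-c3ccc(C(F)(F)F)cc3)cs2)ccc1C(C)C` gives 93 nM. Of these two numbers, compound 2 carries the higher one, yet the gap to compound 1 lies within the usual scatter of such measurements, so the two compounds cannot be told apart on this evidence.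

Compound 3 `O=C(O)CCNC(=O)c1ccc(CN(c2ccc(OC(F)(F)F)cc2)c2nc(-c3ccc(C(F)(F)F)cc3)cs2)cc1` is the next candidate. Compared with compound 2 it differs in one place: 4-(trifluoromethoxy)phenyl in place of 4-isopropyl-3-methylphenyl on a nitrogen on an aromatic ring. The group that enters is the very group compound 1 carries on that same nitrogen, while the rest of compound 3 matches compound 2.

Within the data shown here, no measured step covers this exchange. Because compound 1 gives 53 nM with the entering group in place, compound 3 is expected to show a step of about a 1.6-fold lower number from compound 2 to compound 3 (0.19 log units; within the scatter), a shift no larger than the scatter. Compound 3 is therefore estimated at 60 nM, within a range from 25 nM to 150 nM.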

Compound 3, half-maximal inhibitory concentration: 51 nM
Compound 3: middle estimate off by 1.2-fold (0.07 log units), on the high side; the measured number falls inside the stated range.
By their numbers in this assay, from the lowest: compounds 3, 1 and 2 (each within the scatter of the next).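

Among these compounds, this is the first comparison here between two compounds that differ in one place, so the group on this nitrogen can now be judged alone. Replacing 4-isopropyl-3-methylphenyl with 4-(trifluoromethoxy)phenyl gives a 1.8-fold lower number from compound 2 to compound 3 (0.26 log units; within the scatter) and so leaves the two compounds indistinguishable in this assay even though the entering group brings oxygen, fluorine and a hydrogen-bond acceptor to a group that was all carbon. No other measurement accompanies this result, so the data offer no explanation for it.

Only these two groups have been compared directly at this position, and both are substituted phenyl rings. Going by these compounds, it remains open whether an unsubstituted phenyl, a pyridine or a ring carrying an amine on this nitrogen would also give a number within the scatter of these two.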